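The source may report more compounds than this note shows. Statements on the series, on what has been measured and on what is new or still open speak of the compounds shown alone.

Compound 1 `COc1ccc(S(=O)(=O)Nc2ccc(-c3nc4ccccc4o3)cc2)cc1`: > 100000 nM, a limit.
Compound 2 `Cc1ccccc1S(=O)(=O)Nc1ccc2oc(-c3ccccc3)nc2c1`: 57000 nM.
Compound 3 `C=Cc1ccc(S(=O)(=O)Nc2ccc(-c3nc4ccccc4o3)cc2)cc1`: > 100000 nM, a limit.

Among the measured compounds shown here, in an ADME assay on HEK293 cells (Homo sapiens) for cytotoxicity, read by resazurin assay, with a stated time of 48 h (a higher number here means that more compound is tolerated, a lower number that less compound is tolerated), compound 2 stands as the only number among the three values; the other two are limits, summarised as the limit of > 100000 nM in this assay, at which 2 of the 3 values shown sit. For the measured compounds named here, the one step between measured compounds, a step that the two limits leave unreadable from compound 1 to compound 3, gives no readable size. Compound 4 `O=S(=O)(Nc1ccc2oc(-c3ccccc3)nc2c1)c1cccs1` differs from compound 2 by thiophen-2-yl in place of 2-methylphenyl on a sulfonyl sulfur. Going by the values given here, no measured step touches the group on the sulfonyl sulfur, so nothing sets a direction for this change. Compound 4 is therefore expected to stay close to compound 2, an expected step of a 1.1-fold higher number from compound 2 to compound 4 (0.02 log units; within the scatter), no more than the usual scatter. The estimate for compound 4 in this assay is 60000 nM, between 25000 nM and 150000 nM.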

Compound 4, half-maximal cytotoxic concentration: 97000 nM
Estimate against measurement, compound 4: 1.6-fold (0.21 log units) below, within the range that was stated.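

In this assay, among the compounds shown here, thiophen-2-yl in place of 2-methylphenyl on a sulfonyl sulfur gives the first readable step at this position: a 1.7-fold higher number from compound 2 to compound 4 (0.23 log units; within the scatter). One aromatic ring therefore replaces another here without separating the two compounds beyond the scatter. Steps involving the limits cannot be read, so the series still offers no second size for comparison: the limit of > 100000 nM in this assay, at which 2 of the 4 values shown sit.

One step sets no trend for this position. From the compounds shown here alone, what a butyl chain or an amine on the sulfonyl sulfur would give stays open.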